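This account rests on a few compounds, and the source may have more. Where it says the series, first, only, none or still open, it means among the compounds named here.

In a physicochemical assay for solubility, at pH 7 (on this read-out higher numbers stand for higher solubility and lower numbers for lower solubility), compound 1 (`CN1CCC(C(=O)N2Cc3c(NC(=O)NCc4ccccc4)n[nH]c3C2(C)C)CC1`) gives > 225000 nM as its reading, which is a limit and not a number. Compound 2 (`CN1CCC(C(=O)N2Cc3c(NC(=O)c4ccco4)n[nH]c3C2(C)C)CC1`) gives > 225000 nM as its reading, again only a limit. Compound 3 (`CN1CCC(C(=O)N2Cc3c(NC(=O)Nc4cccc(F)c4)n[nH]c3C2(C)C)CC1`) differs from compound 2 by (3-fluorophenyl)amino in place of furan-2-yl on a carbonyl carbon with (3-fluorophenyl)amino in place of furan-2-yl on a carbonyl carbon. The evidence is the limit of > 225000 nM in this assay, at which 2 of the 2 values shown sit, and nothing more. For the measured compounds named here, the one measured step is a step that the two limits leave unreadable from compound 1 to compound 2 and it gives no size, so no change beyond the scatter is expected in this assay on going to compound 3. The expected step is an at least 1.1-fold lower number from compound 2 to compound 3 (0.07 log units; that floor lies within the scatter) in this estimate. The estimate for compound 3 is 190000 nM with an expected range from 70000 nM to 225000 nM for now.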

Compound 3, solubility: > 225000 nM
Compound 3 was reported as a limit; the forecaster's own chance of this, stated with the estimate: 60%; at least 1.1-fold (0.07 log units) between middle value and limit.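

For the compounds shown here, compound 1, compound 2 and compound 3 each give only a limit in this assay, and no step among them can be read. On these data alone, how far their true numbers lie past that limit, and whether they differ at all, stays open.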